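One added methyl on a weak antiproliferative compound

A few compounds are considered here, and "the series" means these few. Any claim that something is new, unique, unknown or untested is made for them only; others in the source may bear on it.

So far, two compounds have been measured in a functional assay on HeLa cells (Homo sapiens) for antiproliferative activity, read by MTT assay, with a stated time of 72 h; a lower number here means a stronger inhibitor, a higher number a weaker inhibitor. Compound 1 (`COc1cccc(Nc2nc3c(c(Oc4cccc(NC(=O)/C=C/C(C)C)c4)n2)CSCC3)c1`) gives > 50000 nM, which is a limit of the assay and not a number. Within the data shown here, compound 2 (`CC/C=C/C(=O)Nc1cccc(Oc2nc(Nc3ccc(OC)cc3)nc3c2CSCC3)c1`) gives 27200 nM, the only actual number available, and so it has no measured value to be ranked against.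

Compound 3 (`COc1ccc(Nc2nc3c(c(Oc4cccc(NC(=O)/C=C/C(C)C)c4)n2)CSCC3)cc1`) differs from compound 2 in one place: methyl in place of hydrogen on a saturated chain carbon bound to a double-bonded chain carbon and a saturated chain carbon. Cut one bond further out, the same difference reads as ethyl to isopropyl. Among the measured compounds shown here, no measured step between close relatives is available to size this change. With compound 2 at 27200 nM as the only anchor, no shift beyond the scatter is expected in this assay, in either direction. The expected step of a 1.1-fold higher number from compound 2 to compound 3 (0.04 log units; within the scatter) is therefore small. Compound 3 is estimated at 30000 nM. The expected range for this compound runs from 13000 nM to 60000 nM, and a reading that reaches only the limit of the assay would not be a surprise.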

Compound 3, half-maximal inhibitory concentration: 22900 nM
Compound 3: the middle estimate sits 1.3-fold (0.12 log units) above what was measured; the range from low to high includes it.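

In this assay, the added methyl that turns but-1-en-1-yl into 3-methylbut-1-en-1-yl gives a 1.2-fold lower number from compound 2 to compound 3 (0.07 log units; within the scatter), so this first direct reading at the saturated chain carbon shows no shift that can be told from the scatter. The change of 4-methoxyphenyl in place of 3-methoxyphenyl on a nitrogen on an aromatic ring, with the chain held the same, gives an at least 2.1-fold lower number from compound 1 to compound 3 (0.33 log units; beyond the scatter), and this is the only step shown that lies beyond the scatter, so among these compounds a readable difference appears at that group and not on the chain. Compound 1 stands at a limit of the assay and not at a number, so this step has only a lower bound and its full size stays unknown: the limit of > 50000 nM in this assay, at which 1 of the 3 values shown sits.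

The compounds shown leave open whether a longer chain, or an amine or a carboxylic acid on the chain, would move the number further than a single methyl does. They also leave open whether a 2-methoxyphenyl or a 4-fluorophenyl on the same nitrogen would differ from the 4-methoxyphenyl of compound 3, which gives 22900 nM.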